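Swapping imidazole for triazole on a small core

The source may report more compounds than this note shows. Statements on the series, on what has been measured and on what is new or still open speak of the compounds shown alone.

Measured in a functional assay (trachea) with Cavia porcellus as the target (on this read-out lower numbers stand for stronger inhibition and higher numbers for weaker inhibition), so far
Compound 1 `O=c1c2ccccc2c(-c2cccnc2)nn1CCSc1ccccc1` with 9120 nM
Compound 2 `O=C(O)Cn1nc(-c2cccnc2)c2ccccc2c1=O` with > 100000 nM as a limit, not a number
Compound 3 `Oc1nnc(-n2ccnc2)c2ccccc12` with 8320 nM

Compound 3 (at 8320 nM) stands level with compound 1 (at 9120 nM), the two lying within the scatter of repeated measurements. For compound 2 only a limit is known (> 100000 nM).

Compound 4 `Oc1nnc(-n2cncn2)c2ccccc12` has not yet been measured. Compared with compound 3, it carries 1H-1,2,4-triazol-1-yl in place of 1H-imidazol-1-yl on an aromatic carbon.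

For the measured compounds named here, only one measured step is available (an at least 10-fold higher number from compound 1 to compound 2 (1.04 log units; beyond the scatter)). It is large, but it exchanges different groups on a chain that compound 3 does not have, so it gives no direct measure for this swap. It does show that numbers in this assay can climb far, which argues for a wide range on the upper side. The swap keeps a five-membered aromatic ring in the same place, so only a small step is expected, possibly within the scatter and leaning towards a higher number. The expected change is a 1.7-fold higher number from compound 3 to compound 4 (0.23 log units; within the scatter) in this estimate. For compound 4 the estimated value is 14000 nM (expected range 4000 nM to 50000 nM).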

Compound 4, half-maximal inhibitory concentration: 16600 nM
Compound 4: middle estimate off by 1.2-fold (0.07 log units), on the low side; measured number inside the range.
By their numbers in this assay, from the lowest: compounds 3, 1 and 4 (each within the scatter of the next). At a limit, above all of these: compound 2.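

In this assay, for the compounds shown here, replacing 1H-imidazol-1-yl with 1H-1,2,4-triazol-1-yl on the aromatic carbon para to a hydroxy group gives a 2.0-fold higher number from compound 3 to compound 4 (0.30 log units; within the scatter), the first measured exchange between two such rings at this position. The entering ring has the same 5 heavy atoms but carries 3 hetero atoms instead of 2 and 3 hydrogen-bond acceptors instead of 2, and this difference produces a step that cannot be told apart from the scatter of repeated measurements, so these two rings cannot be ranked in this assay. Compound 2 remains the only compound held at a limit, which is not a number, and this swap gives no sign of a comparable climb: the limit of > 100000 nM in this assay, at which 1 of the 4 values shown sits.

As far as these compounds go, compounds 3 and 4 both carry a five-membered aromatic ring at this position, so how a simple amine or a longer chain would read there remains open. Also open, from the compounds shown here alone, is what would happen if the hydroxy group on the shared core gave way to a methoxy group, as the hydroxy group is the same in compounds 3 and 4.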